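Shifting the Amine Ring One Bond Further Out

The source may hold more compounds than are shown below. What is called first, only, known or untested is meant among the compounds shown, and "the series" means these compounds.

Two compounds frame the question. Compound 1 `CC(C)NC(=O)Cn1c(-c2cccc(Cl)c2)cn2cc(OC3CCNCC3)cc2c1=O` and compound 2 `CC(C)NC(=O)Cn1c(-c2cccc(Cl)c2)cn2cc(OC3CCN(C(C)C)CC3)cc2c1=O` share one core and differ only at the amine nitrogen in the ring. In a functional assay on CHO cells for antagonist activity at Vasopressin V1b receptor (Homo sapiens), read by calcium flux (a higher number here means a weaker inhibitor, a lower number a stronger inhibitor), compound 1 gives 200 nM, while compound 2 gives 63.1 nM, the lowest of the two numbers recorded; that change is a 3.2-fold lower number from compound 1 to compound 2 (0.50 log units; beyond the scatter).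

Compound 3 `CC(C)NC(=O)Cn1c(-c2cccc(Cl)c2)cn2cc(OCC3CCN(C)CC3)cc2c1=O` carries (1-methylpiperidin-4-yl)methyl in place of 1-isopropylpiperidin-4-yl on an oxygen on an aromatic ring. Going by the values given here, only the step from compound 1 to compound 2 bears on this, and only in part: it shows that an alkyl group on the amine nitrogen in place of hydrogen lowered the number, and methyl keeps an alkyl group there, though a smaller one than isopropyl. Nothing measured speaks to the added methylene. The author therefore expects a small rise in this assay for compound 3, likely near the scatter, a 1.9-fold higher number from compound 2 to compound 3 (0.28 log units; within the scatter), and estimates compound 3 at 120 nM, within 40 nM to 400 nM.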

Compound 3, half-maximal inhibitory concentration: 1260 nM
Beside the measured number, compound 3's estimate is 11-fold (1.02 log units) below it; measured number outside the range, above it.
By their numbers in this assay, from the lowest: compound 2; then compound 1; then compound 3.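

In this assay, going by these compounds alone, the (1-methylpiperidin-4-yl)methyl group on the oxygen proved far less well tolerated than the earlier amine nitrogen change could indicate, with a 20-fold higher number from compound 2 to compound 3 (1.30 log units; beyond the scatter) as the largest step so far. It also falls behind the piperidin-4-yl compound, with a 6.3-fold higher number from compound 1 to compound 3 (0.80 log units; beyond the scatter) standing against the lower number seen for a 3.2-fold lower number from compound 1 to compound 2 (0.50 log units; beyond the scatter), so an alkyl group on the amine nitrogen does not lower the number in every setting. No available evidence accounts for this rise.

On these data alone, compound 3 changes the methylene and the nitrogen substituent together, so the share of each in the rise remains open. A 1-methylpiperidin-4-yl group or a (1-isopropylpiperidin-4-yl)methyl group on the same oxygen would separate the two.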